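The source may hold more compounds than are shown below. What is called first, only, known or untested is meant among the compounds shown, and "the series" means these compounds.

Working notes on the series. Compound 3 `CCC(CC)c1ccc2c(NCCCNCc3cc(F)ccc3OC)ccnc2c1` gives 9.47 in a physicochemical assay for acid dissociation, level with compound 1 `COc1ccc(F)cc1CNCCCNc1ccnc2cc(Cc3ccc(F)cc3)ccc12` at 9.47 and together the highest of the three numbers, with compound 2 `COc1ccc(F)cc1CNCCCNc1ccnc2cc(Oc3ccc(C(C)(C)C)cc3)ccc12` at 9.28 the furthest away. Among the compounds with values here, the step of a number 0.19 log units higher from compound 2 to compound 3 (within the scatter) is the only one that swaps an aryl ether for the pentan-3-yl group, and a number 0.19 log units lower from compound 1 to compound 2 (within the scatter) points the same way. Compound 4 `COc1ccc(F)cc1CNCCCNc1ccnc2cc(Oc3ccc(Cl)cc3)ccc12` differs from compound 3 as follows: 4-chlorophenoxy in place of pentan-3-yl on an aromatic carbon. Since both steps involving 4-(tert-butyl)phenoxy stayed within the scatter, no step beyond the scatter is expected here, perhaps a slight drift downward as in compound 2. The estimated step of a number 0.15 log units lower from compound 3 to compound 4 (within the scatter) is expected to be small. For compound 4 the estimate is 9.32, within 9.02 to 9.62.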

Compound 4, acid dissociation constant: 9.28
Compound 4: the middle estimate sits 0.04 log units above what was measured; measured number inside the range.
By their numbers in this assay, from the lowest: compounds 2, 4, 1 and 3 (each within the scatter of the next).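

In this assay the step of no change at the digits printed from compound 2 to compound 4 (within the scatter) comes with chloro in place of tert-butyl on an aromatic carbon, so the two aryl ethers give the same printed number. The steps of a number 0.19 log units lower from compound 3 to compound 4 (within the scatter) and a number 0.19 log units lower from compound 1 to compound 4 (within the scatter) show that 4-chlorophenoxy also stays within the scatter of both pentan-3-yl and 4-fluorobenzyl. All four groups at this position therefore lie within the scatter of one another. No supporting data bear on this flat picture. On these data alone, whether a group carrying an amine or a carboxylic acid here would stay within the scatter remains open.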